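The compounds below may be only part of what the source reports. "The series", "measured", "known", "first", "only" and "open" are said of these compounds alone.

Measured compounds:
- compound 1, `N#C/C(=C\c1ccc([N+](=O)[O-])cc1)C(=O)c1c[nH]c2ccccc12`: 59000 nM
- compound 2, `COc1ccc(CNC(=O)/C(C#N)=C/c2ccc[nH]2)cc1`: > 50000 nM

The measurements come from a functional assay on DU-145 cells (Homo sapiens) for inhibition, read by MTT assay, with a stated time of 72 h; a higher number here means a weaker inhibitor of growth, a lower number a stronger inhibitor of growth. Compound 1 gives 59000 nM in this assay, a weak result. Compound 2 returns only a limit, > 50000 nM, in this assay, so no number is known for it; that limit is described by the limit of > 50000 nM in this assay, at which 1 of the 2 values shown sits. Compound 2 therefore stands at the weak end of everything shown here, and its true value is not pinned down.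

Compound 3, `COc1ccc(CNC(=O)/C(C#N)=C/c2ccc(Br)o2)cc1`, has not yet been measured in this assay. It differs from compound 2 in one place: 5-bromofuran-2-yl in place of 1H-pyrrol-2-yl on a double-bonded chain carbon bound to a double-bonded chain carbon. Within the data shown here, with only two measured values and no measured step between them, there is nothing in the data to say how this exchange of one five-membered aromatic ring for another will move the result in this assay.

The step from compound 2 to compound 3 is expected to be small or none beyond the scatter, an at least 1.1-fold lower number from compound 2 to compound 3 (0.04 log units; that floor lies within the scatter). For compound 3 in this assay the estimate is 45000 nM, with a range from 12000 nM to 200000 nM, and a real chance that it again returns only a limit.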

Compound 3, concentration for 50% growth inhibition: 12000 nM
The estimate for compound 3 lay 3.8-fold (0.57 log units) above the measured number; measured number inside the range.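

The ring on this double-bonded chain carbon can move the result in this assay: with the rest of the molecule unchanged, 5-bromofuran-2-yl in place of 1H-pyrrol-2-yl gives an at least 4.1-fold lower number from compound 2 to compound 3 (0.61 log units; beyond the scatter), and this step lies beyond the scatter. Among these compounds, it is the first step between measured compounds here, and it shows that a change at this single place is enough to move the result. Compound 3 gives 12000 nM, a measured number. The step is a minimum and its full size remains unknown because compound 2 returns only a limit, not a number: the limit of > 50000 nM in this assay, at which 1 of the 3 values shown sits.

The change swaps the ring's hetero atom, adds a bromine and removes a hydrogen-bond donor all at once, and the compounds shown cannot say which of these accounts for the step. Plain furan-2-yl or 5-bromo-1H-pyrrol-2-yl at this place would separate the ring from the bromine, and 5-chlorofuran-2-yl or 5-methylfuran-2-yl would test whether bromine itself is needed.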